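The source may report more compounds than this note shows. Statements on the series, on what has been measured and on what is new or still open speak of the compounds shown alone.

Series notes. The shared core of compound 1 `O=C(OC1CCC(CN2CCN(c3cc(=O)c4cc(C(F)(F)F)cc([N+](=O)[O-])c4s3)CC2)CC1)C1CCC1` carries a cyclobutyl group on a carbonyl carbon; compound 2 `Cc1ccc(C(=O)OC2CCC(CN3CCN(c4cc(=O)c5cc(C(F)(F)F)cc([N+](=O)[O-])c5s4)CC3)CC2)cc1` carries 4-methylphenyl at that carbonyl carbon, and compound 3 `COc1ccccc1C(=O)OC1CCC(CN2CCN(c3cc(=O)c4cc(C(F)(F)F)cc([N+](=O)[O-])c4s3)CC2)CC1` carries 2-methoxyphenyl there. In an ADME assay on Vero cells (Chlorocebus sabaeus) for cytotoxicity, read by MTT assay, with a stated time of 48 h (on this read-out higher numbers stand for weaker inhibition and lower numbers for stronger inhibition), compound 1 gives > 64 ug/mL, which is a limit of the assay and not a number. In this assay compound 2 likewise gives a limit, > 64 ug/mL. Compound 3 sits at a limit as well, > 64 ug/mL. Compound 3 therefore stands where every value shown in this assay stands, namely at the limit of > 64 ug/mL in this assay, at which 3 of the 3 values shown sit. The steps a step that the two limits leave unreadable from compound 1 to compound 2, a step that the two limits leave unreadable from compound 1 to compound 3 and a step that the two limits leave unreadable from compound 2 to compound 3 are consequently without readable size.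

Compound 4 `COc1ccc(C(=O)OC2CCC(CN3CCN(c4cc(=O)c5cc(C(F)(F)F)cc([N+](=O)[O-])c5s4)CC3)CC2)cc1` differs from compound 3 by 4-methoxyphenyl in place of 2-methoxyphenyl on a carbonyl carbon. All three measured steps exchange the group on the carbonyl carbon, and none of them moved a value off the limit, so the step to compound 4 in this assay is expected to be none beyond the scatter, a step that the limit leaves unreadable from compound 3 to compound 4. For compound 4 a value of 80 ug/mL is estimated, within 40 ug/mL to 160 ug/mL, with the most probable outcome being once more a limit rather than a number.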

Compound 4, half-maximal inhibitory concentration: > 64 ug/mL
Compound 4: only a limit was reported; the forecaster's own chance of this, stated with the estimate: 85%; the middle value lies beyond the limit too.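

In this assay compound 4 gives > 64 ug/mL as a limit and not a number. For the compounds shown here, no step between compound 4 and compound 1, compound 2 or compound 3 can be read. The compounds shown leave open whether any group on the carbonyl carbon of the shared core gives a readable value in this assay at all.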